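Aryl swap on a furoate ester: from dichlorophenyl to methylphenyl

The source may hold more compounds than are shown below. What is called first, only, known or untested is meant among the compounds shown, and "the series" means these compounds.

The series rests on one ester core. Compound 1 `CCOc1cc(COC(=O)c2ccc(-c3ccccc3)o2)cc(OCC)c1OCC` gives 30.8% in an assay on isolated protein for inhibition of high affinity 3',5'-cyclic-AMP phosphodiesterase 7A (Homo sapiens), read by scintillation proximity assay and cAMP accumulation, with a stated time of 20 min, tested at 10 uM (a higher number here means more inhibition at the concentration tested (going by the name of the read-out), a lower number less inhibition), and compound 2 `CCOc1cc(COC(=O)c2ccc(-c3ccc(Cl)cc3Cl)o2)cc(OCC)c1OCC` gives 31.1% in this assay. For the measured compounds named here, the only measured step, a number 0.3 percentage points higher from compound 1 to compound 2 (within the scatter), leaves the two compounds within the scatter of each other, so compound 2 stands at a number that cannot be told apart from that of compound 1.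

Compound 3 `CCOc1cc(COC(=O)c2ccc(-c3ccc(C)cc3)o2)cc(OCC)c1OCC` differs from compound 2 in one place: 4-methylphenyl in place of 2,4-dichlorophenyl on an aromatic carbon. The step from compound 1 to compound 2 bears on this change, since it also exchanges the substituent on the same aromatic carbon, and that step was within the scatter. A step of no size beyond the scatter is therefore expected, a number 0.1 percentage points lower from compound 2 to compound 3 (within the scatter). Compound 3 is estimated to give 31% in this assay, with a range from 18% to 44%.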

Compound 3, a percentage reported as inhibition, at one concentration (the size of the read-out at that concentration, not a potency): 28%
For compound 3 the middle estimate is 3 percentage points above the measured one, and the stated range covers the measured number.
By their numbers in this assay, from the lowest: compounds 3, 1 and 2 (each within the scatter of the next).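

Two further steps bear on this position in this assay: a number 3.1 percentage points lower from compound 2 to compound 3 (within the scatter) for 4-methylphenyl in place of 2,4-dichlorophenyl, and a number 2.8 percentage points lower from compound 1 to compound 3 (within the scatter) for methyl in place of hydrogen on an aromatic carbon. The earlier pair tested only the two chlorines, whereas a methyl group now also leaves the number within the scatter, so phenyl, 2,4-dichlorophenyl and 4-methylphenyl cannot be told apart here. Nothing available explains this insensitivity.

From the compounds shown here alone, whether an amine or a carboxylic acid on that phenyl ring would move the number beyond the scatter remains open. Equally open, going by these compounds, is how these three compounds compare in potency, for which a percentage at one concentration gives no measure.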